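Methyl Removal on a Chromone Core and Antiproliferative Readout

This account rests on a few compounds, and the source may have more. Where it says the series, first, only, none or still open, it means among the compounds named here.

The measured compounds:
compound 1, `CC/C=C\C/C=C\C/C=C\CCCCCCCc1cc(=O)c2c(O)cc(O)cc2o1`, 17500 nM in a functional assay on MCF7 cells (Homo sapiens) for antiproliferative activity, read by MTT assay; on this read-out lower numbers stand for stronger inhibition and higher numbers for weaker inhibition
compound 2, `CC/C=C\C/C=C\C/C=C\CCCCCCCc1cc(=O)c2c(O)c(C)c(O)cc2o1`, 17500 nM in this assay
compound 3, `CCCC/C=C\CCCCCCCCCc1cc(=O)c2c(O)c(C)c(OCOC)c(C)c2o1`, a limit of > 67200 nM in this assay

For compound 3 this assay gives only a limit, (the limit of > 67200 nM in this assay, at which 1 of the 3 values shown sits). The difference between the core of compound 2 and the core of compound 3 is not broken down here. Between compound 2 and compound 1 the change is hydrogen in place of methyl on an aromatic carbon, and it gives no change at the digits printed from compound 2 to compound 1 (within the scatter).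

Compound 4, `CCCC/C=C\CCCCCCCCCc1cc(=O)c2c(O)cc(OCOC)c(C)c2o1`, is not yet measured. It differs from compound 3 by hydrogen in place of methyl on an aromatic carbon. This is the same kind of change as that from compound 2 to compound 1, but the surroundings differ: here the carbon is ortho to a hydroxy group and ortho to a methoxymethoxy group and meta to a methyl group, whereas in compound 2 it is ortho to two hydroxy groups. Resting on the measured step of no change at the digits printed from compound 2 to compound 1 (within the scatter), the step of a number no higher from compound 3 to compound 4 (the limit leaves the size open) is expected. Compound 4 is therefore estimated at 67200 nM in this assay, within 25000 nM to 150000 nM, and most likely again only a limit.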

Compound 4, half-maximal inhibitory concentration: > 67200 nM
Compound 4: no number, only a limit; the forecaster's own chance of this, stated with the estimate: 70%; the middle value lies on the limit itself.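

In this assay compound 4 gives > 67200 nM, which is a limit and not a number, and compound 3 also has only a limit, so no step between compound 3 and compound 4 can be read: the limit of > 67200 nM in this assay, at which 2 of the 4 values shown sit.

The compounds shown leave open what hydrogen in place of methyl on an aromatic carbon does to the read-out in the surroundings of compound 3.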